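The compounds below may be only part of what the source reports. "The series", "measured", "known", "first", "only" and "open" are said of these compounds alone.

Compound 1 `CCOC(=O)CCCCCOc1cccc(CN(C(=O)c2ccc(-c3cnc(OC)nc3OC)cc2)C(C)C)c1` was tested in an ADME assay on Raji cells (Homo sapiens) for cytotoxicity, read by CellTiter-Glo and resazurin assay, with a stated time of 72 h (on this read-out lower numbers stand for an effect already at smaller amounts and higher numbers for an effect only at larger amounts of compound), where it produced no measurable effect: the reading for compound 1 is the limit of the test, > 26000 nM, so only a limit and no number is known for it. Compound 2 `CCOC(=O)CCCCCOc1cccc(CN(C(=O)c2ccc(-c3cn(S(=O)(=O)c4ccccc4)c4ccccc34)cc2)C(C)C)c1`, which carries a different group at the same position, likewise reached only the limit of this assay, > 26000 nM. Within the data shown here, both measured compounds therefore sit at the limit of > 26000 nM in this assay, at which 2 of the 2 values shown sit, and no step between two measured numbers can be counted.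

Compound 3 `CCOC(=O)CCCCCOc1cccc(CN(C(=O)c2ccc(-c3ccc(Cl)c(Cl)c3)cc2)C(C)C)c1` is the next compound in this series. It differs from compound 1 in one place: 3,4-dichlorophenyl in place of 2,4-dimethoxypyrimidin-5-yl on an aromatic carbon. Since compound 1 and compound 2 give the same limit in this assay, the step from compound 1 to compound 3 is expected to be none beyond the usual scatter, that is a step that the limit leaves unreadable from compound 1 to compound 3. On that basis compound 3 is estimated to give about 40000 nM in this assay, with a range from 15000 nM to 150000 nM, and most likely again only a limit.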

Compound 3, half-maximal effective concentration: > 26000 nM
Compound 3 was reported as a limit; the forecaster's own chance of this, stated with the estimate: 75%; the middle value lies beyond the limit too.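

Compound 3 gives only a limit in this assay, > 26000 nM. Compound 1 also gives only a limit, so no step from compound 1 to compound 3 can be read: the limit of > 26000 nM in this assay, at which 3 of the 3 values shown sit.

The compounds shown leave open what amount of any of them would produce an effect on these cells, and whether exchanging the group on the aromatic carbon changes that amount at all.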